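Triazole in place of the amine on the macrocycle side chain

The source may hold more compounds than are shown below. What is called first, only, known or untested is meant among the compounds shown, and "the series" means these compounds.

Measured compounds:
compound 1 `COC/C1=C/C[C@](C)(CCC=C(C)C)/C=C/[C@@H](OC(=O)C=C(C)C)[C@](C)(OC)/C=C/C1=O` — 4050 nM
compound 2 `C=C1/C=C/C(=O)/C(CO)=C\C[C@](C)(CCC=C(C)C)/C=C/[C@H]1OC(=O)C=C(C)C` — 2810 nM
compound 3 `CCN(CC)C/C1=C/C[C@](C)(CCC=C(C)C)/C=C/[C@@H](OC(=O)C=C(C)C)[C@](C)(O)/C=C/C1=O` — 140 nM

In a functional assay on HL-60 cells (Homo sapiens) for antiproliferative activity, read by MTT assay, with a stated time of 48 h (on this read-out higher numbers stand for weaker inhibition and lower numbers for stronger inhibition), compound 3 gives the lowest number of the three. The nearest value is that of compound 2, which is beyond the scatter, and the furthest is that of compound 1, also beyond the scatter. Going by the values given here, compound 3 thus stands apart from the other two as the strongest inhibitor in this assay on the numbers so far.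

Compound 4 `CC(C)=CCC[C@]1(C)/C=C/[C@@H](OC(=O)C=C(C)C)[C@](C)(O)/C=C/C(=O)/C(Cn2cc(CO)nn2)=C\C1` has not yet been measured in this assay. The change from compound 3 is 4-(hydroxymethyl)-1H-1,2,3-triazol-1-yl in place of diethylamino on a saturated chain carbon bound to a double-bonded ring carbon. Among the compounds with values here, no single-point step between measured compounds is available to calibrate this change; the two weaker compounds differ from compound 3 in more than one place, so their values only show that the series spans a wide range in this assay.

The diethylamino group leaves and a ring with a hydroxymethyl group enters in its place. The step from compound 3 to compound 4 is expected to be an 11-fold higher number from compound 3 to compound 4 (1.03 log units; beyond the scatter), beyond the scatter, in the direction of a higher number. Compound 4 is therefore estimated at 1500 nM, with a likely range from 400 nM to 5000 nM, closer to the values of compound 1 and compound 2 than to that of compound 3.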

Compound 4, half-maximal inhibitory concentration: 3200 nM
Estimate against measurement, compound 4: 2.1-fold (0.33 log units) below; the range from low to high includes it.
By their numbers in this assay, from the lowest: compound 3; then compounds 2, 4 and 1 (each within the scatter of the next).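

In this assay, 4-(hydroxymethyl)-1H-1,2,3-triazol-1-yl in place of diethylamino on a saturated chain carbon bound to a double-bonded ring carbon gives a 23-fold higher number from compound 3 to compound 4 (1.36 log units; beyond the scatter) as a large step, the first in the series that can be read for one place alone. Going by these compounds alone, the earlier compounds differed from one another in more than one place, so only this pair shows that a change at this position, with the rest of the shared core held constant, is enough to move the number well beyond the scatter. Nothing at hand accounts for the size of this step or tells whether the departing diethylamino group or the entering ring counts for more.

From the compounds shown here alone, whether the value of compound 3 at 140 nM is tied to diethylamino in particular or is shared by other amines remains open. Pyrrolidine or morpholine on the same carbon would address that, while a triazole carrying a carboxylic acid or a longer chain in place of hydroxymethyl would show whether the ring itself or its substituent sets the number of compound 4.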